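Lengthening the hydroxycarbamoyl chain of compound 1

The compounds below may be only part of what the source reports. "The series", "measured", "known", "first", "only" and "open" are said of these compounds alone.

Measured in a functional assay on A549 cells (Homo sapiens) for antiproliferative activity, read by CCK-8 assay, with a stated time of 72 h; on this read-out lower numbers stand for stronger inhibition and higher numbers for weaker inhibition:
- compound 1 `CCOc1cc(C(C)(C)C)ccc1C1=NC(c2ccc(Cl)cc2)C(c2ccc(Cl)cc2)N1C(=O)N1CCN(CCCCCC(=O)NO)CC1`: 2910 nM
- compound 2 `CCOc1cc(C(C)(C)C)ccc1C1=NC(c2ccc(Cl)cc2)C(c2ccc(Cl)cc2)N1C(=O)NCCCCCCCC(=O)NO`: 4850 nM

Compound 1 and compound 2 lie within the scatter of each other, so the measured pair does not separate. Compound 3 `CCOc1cc(C(C)(C)C)ccc1C1=NC(c2ccc(Cl)cc2)C(c2ccc(Cl)cc2)N1C(=O)N1CCN(CCCCCCCC(=O)NO)CC1` differs from compound 1 by 2-(hydroxycarbamoyl)ethyl in place of hydroxycarbamoyl on a saturated chain carbon, five bonds along the chain from an amine nitrogen in a ring. For the measured compounds named here, no measured pair isolates this change, so in this assay no step beyond the scatter is expected, and the expectation rests on compound 1 at 2910 nM and compound 2 at 4850 nM. The expected result is a 1.0-fold lower number from compound 1 to compound 3 (0.02 log units; within the scatter). Compound 3 is estimated at 2800 nM, with an expected range of 1200 nM to 6500 nM.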

Compound 3, half-maximal inhibitory concentration: 2010 nM
Beside the measured number, compound 3's estimate is 1.4-fold (0.14 log units) above it; the measured number falls inside the stated range.
By their numbers in this assay, from the lowest: compounds 3, 1 and 2 (each within the scatter of the next, the first and the last beyond it).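

At this saturated chain carbon, five bonds along the chain from an amine nitrogen in a ring, 2-(hydroxycarbamoyl)ethyl in place of hydroxycarbamoyl gives a 1.4-fold lower number from compound 1 to compound 3 (0.16 log units; within the scatter) in this assay. This added chain length therefore leaves the antiproliferative read-out unseparated from that of compound 1. No available evidence bears on this result.

Going by these compounds, whether 5-(hydroxycarbamoyl)pentyl at this place also stays within the scatter of compound 1 remains open. So does the outcome of a carboxylic acid replacing the hydroxycarbamoyl end of the chain.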